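This account rests on a few compounds, and the source may have more. Where it says the series, first, only, none or still open, it means among the compounds named here.

Compound 1, with the structure `COc1ccc2c(=O)c(/C=C/C(=O)Nc3cccc(Cl)c3)coc2c1`, is the reference point of this small series. For the measured compounds named here, in a functional assay on HeLa cells (Homo sapiens) for inhibition, read by MTT assay, with a stated time of 48 h (a higher number here means a weaker inhibitor, a lower number a stronger inhibitor), compound 1 gives 11900 nM, which is the only number measured in full here. Compound 2, with the structure `COc1ccc2c(=O)c(/C=C/C(=O)Nc3ccccc3)coc2c1`, carries hydrogen in place of chloro on an aromatic carbon. In this assay compound 2 reaches only a limit of > 100000 nM. The step is therefore an at least 8.4-fold higher number from compound 1 to compound 2 (0.92 log units; beyond the scatter), and the limit at which compound 2 sits is recorded as the limit of > 100000 nM in this assay, at which 1 of the 2 values shown sits.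

Compound 3, with the structure `COc1ccc(NC(=O)/C=C/c2coc3cc(OC)ccc3c2=O)cc1`, differs from compound 1 in one place: 4-methoxyphenyl in place of 3-chlorophenyl on an amide-type nitrogen. Going by the values given here, the only measured step that bears on this change is the loss of chloro from compound 1 to compound 2, which cost at least a modest amount of potency. Nothing measured shows what a 4-methoxyphenyl on the amide-type nitrogen does in its own right. A weaker inhibitor is therefore expected, and compound 3 is estimated to give about 40000 nM in this assay, between 10000 nM and 150000 nM, a step of a 3.4-fold higher number from compound 1 to compound 3 (0.53 log units; beyond the scatter) that is expected to be a loss.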

Compound 3, half-maximal inhibitory concentration: 13000 nM
For compound 3 the middle estimate is 3.1-fold (0.49 log units) above the measured one; low and high end bracket the measured number.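

In this assay, 3-chlorophenyl and 4-methoxyphenyl on the amide-type nitrogen cannot be told apart, with a 1.1-fold higher number from compound 1 to compound 3 (0.04 log units; within the scatter). For the compounds shown here, this shows that chloro is not the only group that separates these compounds from the unsubstituted phenyl of compound 2: methoxy in place of hydrogen on an aromatic carbon gives an at least 7.6-fold lower number from compound 2 to compound 3 (0.88 log units; beyond the scatter), a step of similar reach to the one seen with chloro. That step has only a bound for its size, and compound 2 stands at a limit of the assay and not at a number: the limit of > 100000 nM in this assay, at which 1 of the 3 values shown sits.

The compounds shown leave open whether the outcome follows from the group itself or from where it sits on the aromatic ring, as compound 1 and compound 3 differ in both the group and its place. They also leave open what an amine, a carboxylic acid or a longer alkoxy chain would do in place of the chloro or the methoxy, and whether any change on the amide-type nitrogen can move the number beyond the level shared by compound 1 and compound 3.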